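From 1H-indol-6-yl to 4-(dimethylamino)phenyl on the shared core

This account rests on a few compounds, and the source may have more. Where it says the series, first, only, none or still open, it means among the compounds named here.

Of the compounds shown here, three on the shared core have been measured in a functional assay on B16-F0 cells (Mus musculus) for inhibition, read by CCK-8 assay, with a stated time of 48 h; on this read-out higher numbers stand for weaker inhibition and lower numbers for stronger inhibition. With 4-fluorophenyl, compound 1 (`COc1cc(-c2ccnc3cc(-c4ccc(F)cc4)nn23)cc(OC)c1OC`) gives 4540 nM, and with 4-chlorophenyl, compound 2 (`COc1cc(-c2ccnc3cc(-c4ccc(Cl)cc4)nn23)cc(OC)c1OC`) gives 4090 nM. Chloro in place of fluoro gives a 1.1-fold lower number from compound 1 to compound 2 (0.05 log units; within the scatter), so this pair does not separate. With 1H-indol-6-yl, compound 3 (`COc1cc(-c2ccnc3cc(-c4ccc5cc[nH]c5c4)nn23)cc(OC)c1OC`) gives 55 nM, the lowest number of the three and the strongest inhibition among them.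

The next compound is compound 4 (`COc1cc(-c2ccnc3cc(-c4ccc(N(C)C)cc4)nn23)cc(OC)c1OC`), with this change: 4-(dimethylamino)phenyl in place of 1H-indol-6-yl on an aromatic carbon. The exchange is 4-(dimethylamino)phenyl in place of 1H-indol-6-yl on an aromatic carbon. Like compound 1 and compound 2, compound 4 carries one six-membered aromatic ring of carbon only at this place, so the two large steps of an 83-fold lower number from compound 1 to compound 3 (1.92 log units; beyond the scatter) and a 74-fold lower number from compound 2 to compound 3 (1.87 log units; beyond the scatter) bear on it, read in reverse. For the measured compounds named here, no measured compound carries dimethylamino, so only part of that loss is assumed. The expected change is a 13-fold higher number from compound 3 to compound 4 (1.10 log units; beyond the scatter), towards weaker inhibition and beyond the scatter. For compound 4 the estimated value is 700 nM, with an expected range of 150 nM to 4000 nM.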

Compound 4, half-maximal inhibitory concentration: 702 nM
Compound 4: middle estimate off by 1.0-fold (0.00 log units), on the low side; the range from low to high includes it.
By their numbers in this assay, from the lowest: compound 3; then compound 4; then compounds 2 and 1 (each within the scatter of the next).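

In this assay, a single carbon-only six-membered aromatic ring at this place is not tied to the level set by the two halogen compounds: dimethylamino gives a 5.8-fold lower number from compound 2 to compound 4 (0.77 log units; beyond the scatter) and a 6.5-fold lower number from compound 1 to compound 4 (0.81 log units; beyond the scatter), a separation that fluoro and chloro did not produce between themselves. That gain recovers only part of the gap to the fused group, since the exchange gives a 13-fold higher number from compound 3 to compound 4 (1.11 log units; beyond the scatter), and 1H-indol-6-yl keeps the lowest number among these four compounds, with every step to it beyond the scatter. The entering and leaving groups have the same heavy-atom count, so that count alone does not set the number here, while the ring count and the donor and acceptor counts all change together in this one exchange, and no measurement is available to explain either step.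

Going by these compounds, whether dimethylamino can be replaced by a primary amine, methoxy or morpholine without moving the number remains open. Also open, on these data alone, is whether 1-methyl-1H-indol-6-yl or 1H-indol-5-yl stays near compound 3, which would separate the indole hydrogen and the attachment point from the presence of the fused ring.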